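The source may report more compounds than this note shows. Statements on the series, on what has been measured and on what is new or still open speak of the compounds shown alone.

Three ureas that share one diaryl ether core have been measured in a functional assay on MDA-MB-231 cells (Homo sapiens) for inhibition, read by MTT assay and WST assay, with a stated time of 72 h, tested at 10 uM; on this read-out lower numbers stand for less inhibition of growth and higher numbers for more inhibition of growth at the one concentration tested. Compound 1 `O=C(Nc1ccc(Oc2ccc(-c3nccs3)cc2)cc1)Nc1cccc(C(F)(F)F)c1` gives 64.1% in this assay. Compound 2 `O=C(Nc1ccc(Oc2ccc(-c3nccs3)cc2)cc1)Nc1ccc(F)c(Cl)c1` gives 43.9%, so that the step of a number 20.2 percentage points lower from compound 1 to compound 2 (beyond the scatter) follows a change of the aryl group on the urea nitrogen. Compound 3 `O=C(Nc1ccc(Oc2ccc(-c3ncc[nH]3)cc2)cc1)Nc1cccc(C(F)(F)F)c1` gives 28.1%, the lowest of the three numbers, and the step of a number 36 percentage points lower from compound 1 to compound 3 (beyond the scatter) comes with a change of the five-membered ring on the far aromatic ring.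

Compound 4 `O=C(Nc1ccc(Oc2ccc(-c3ncc[nH]3)cc2)cc1)Nc1cc(Br)cc(C(F)(F)F)c1` differs from compound 3 by bromo in place of hydrogen on an aromatic carbon. Neither measured step tests this exact change: the step from compound 1 to compound 2 exchanges one substituted phenyl for another rather than adding a halogen, and the step from compound 1 to compound 3 concerns the five-membered ring, not the urea aryl group. The measured steps therefore give no direct guidance, and the account expects for compound 4 a step of a number 1.9 percentage points higher from compound 3 to compound 4 (within the scatter), which would not stand beyond the scatter. On that basis compound 4 is estimated to give 30% in this assay, with a range from 15% to 48%.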

Compound 4, percent growth inhibition at one concentration: -13.6%
Beside the measured number, compound 4's estimate is 43.6 percentage points above it; the measured number lies below the stated range.
By their numbers in this assay, from the lowest: compound 4; then compound 3; then compound 2; then compound 1.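

The step of a number 41.7 percentage points lower from compound 3 to compound 4 (beyond the scatter) shows that in this assay the 3-(trifluoromethyl)phenyl group does not tolerate every addition: a single bromo, meta to a trifluoromethyl group, goes with a large step, of the same printed size class as the exchange of the five-membered ring in a number 36 percentage points lower from compound 1 to compound 3 (beyond the scatter). The earlier aryl change, a number 20.2 percentage points lower from compound 1 to compound 2 (beyond the scatter), replaced one substituted phenyl with another in the thiazole compounds, whereas this change keeps the trifluoromethyl group, adds one heavy atom, and places compound 4 lowest of the four compounds. Nothing given here accounts for the size of this step.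

The compounds shown leave open whether this step belongs to bromine itself or to any group at this place on the ring, a question that a fluoro, a methyl, a methoxy or an amino group there would address. They also leave open whether the same bromo would give a comparable step on the thiazole compound 1, or whether the step is tied to the 1H-imidazol-2-yl compounds.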